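Ester side-chain variation in a cytotoxicity series

The source may hold more compounds than are shown below. What is called first, only, known or untested is meant among the compounds shown, and "the series" means these compounds.

Measured so far:
compound 1, `CC(C)=CC[C@@H](OC(=O)c1ccco1)C1=CC(=O)c2c(O)ccc(O)c2C1=O`: 80300 nM
compound 2, `CC(C)=CC[C@@H](OC(=O)CCO)C1=CC(=O)c2c(O)ccc(O)c2C1=O`: 67600 nM
compound 3, `CCCCC(C)(O)CC(=O)O[C@H](CC=C(C)C)C1=CC(=O)c2c(O)ccc(O)c2C1=O`: 60600 nM

All three numbers come from a functional assay on HeLa cells (Homo sapiens) for cytotoxicity, read by MTT assay; a lower number here means a stronger inhibitor, a higher number a weaker inhibitor. The three compounds share one core and differ only in the ester on the side chain. Replacing furan-2-yl with 2-hydroxyethyl gives a 1.2-fold lower number from compound 1 to compound 2 (0.07 log units; within the scatter), and with 2-hydroxy-2-methylhexyl gives a 1.3-fold lower number from compound 1 to compound 3 (0.12 log units; within the scatter); between the two hydroxy esters the step is a 1.1-fold lower number from compound 2 to compound 3 (0.05 log units; within the scatter). None of these steps leaves the scatter, so the ester group has so far not moved the read-out in any direction that can be trusted. Compound 3 has the lowest number of the three, but its separation from compound 2 and from compound 1 is within the scatter, so no order among them is claimed.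

Compound 4, `CCCCC(CC(=O)O[C@H](CC=C(C)C)C1=CC(=O)c2c(O)ccc(O)c2C1=O)OC(C)=O`, is not yet measured. It differs from compound 3 as follows: 1-acetoxypentyl in place of 1-hydroxy-1-methylpentyl on a saturated chain carbon bound to a carbonyl carbon. The change sits at the same place as the three steps already seen, all of which were within the scatter. The expectation is therefore a step of a 1.0-fold lower number from compound 3 to compound 4 (0.00 log units; within the scatter), that is, no movement beyond the scatter. For compound 4 the estimate in this assay is 60000 nM, with a range from 25000 nM to 150000 nM.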

Compound 4, half-maximal inhibitory concentration: 73500 nM
For compound 4 the middle estimate is 1.2-fold (0.09 log units) below the measured one; the range from low to high includes it.
By their numbers in this assay, from the lowest: compounds 3, 2, 4 and 1 (each within the scatter of the next).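

In this assay, the ester side chain now also tolerates a change in which the group leaving carries a hydrogen-bond donor and the group entering carries none: 1-acetoxypentyl in place of 1-hydroxy-1-methylpentyl gives a 1.2-fold higher number from compound 3 to compound 4 (0.08 log units; within the scatter) at this place. The same ester set against the shorter hydroxy ester gives a 1.1-fold higher number from compound 2 to compound 4 (0.04 log units; within the scatter) and set against the furan-2-yl ester gives a 1.1-fold lower number from compound 1 to compound 4 (0.04 log units; within the scatter), so capping the oxygen as an acetate adds a fourth ester that cannot be told apart from the other three in this assay, and the absence of a donor in this group does not show up as a separate step. No measurement is available that bears on why the read-out stays flat at this position.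

The step from compound 3 to compound 4 also removes the methyl on the carbinol carbon, so the plain 1-hydroxypentyl group would be needed to separate the acetate from that loss. Whether any group at this place can move the read-out beyond the scatter remains open, as an amine, a carboxylic acid or a much longer chain are not among the compounds shown.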